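Benzoxazole series: furan-2-yl in place of the aryl arm

A few compounds are considered here, and "the series" means these few. Any claim that something is new, unique, unknown or untested is made for them only; others in the source may bear on it.

Three analogues of one shared core have been measured, differing only in the pendant ring. Compound 1 `COc1cccc(-c2nc3cccc(-c4cc(OC)c(OC)c(OC)c4)c3o2)c1` carries 3-methoxyphenyl; in a functional assay on U-251 cells (Homo sapiens) for antiproliferative activity, read by MTT assay, with a stated time of 48 h (a higher number here means a weaker inhibitor, a lower number a stronger inhibitor), compound 1 gives only a limit, > 25000 nM. Compound 2 `COc1ccc(-c2nc3cccc(-c4cc(OC)c(OC)c(OC)c4)c3o2)cc1F` carries 3-fluoro-4-methoxyphenyl and in this assay compound 2 gives 1700 nM. Compound 3 `COc1cc(-c2cccc3nc(-c4ccc(N)cc4)oc23)cc(OC)c1OC` carries 4-aminophenyl and gives 1040 nM. Going by the values given here, compound 2 and compound 3 are the only two numbers, and they sit within the scatter of each other, the step being a 1.6-fold lower number from compound 2 to compound 3 (0.21 log units; within the scatter). Both measured steps from compound 1 are large: an at least 14-fold lower number from compound 1 to compound 2 (1.16 log units; beyond the scatter) and an at least 24-fold lower number from compound 1 to compound 3 (1.38 log units; beyond the scatter), each starting from the limit (the limit of > 25000 nM in this assay, at which 1 of the 3 values shown sits).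

The next compound, compound 4 `COc1cc(-c2cccc3nc(-c4ccco4)oc23)cc(OC)c1OC`, makes a different kind of change: furan-2-yl in place of 3-fluoro-4-methoxyphenyl on an aromatic carbon. Among the compounds with values here, every measured step so far swaps a substituent on a six-membered ring; none removes that ring or introduces a five-membered one, so the measured steps give little direct guidance, and the wide spread between the limit and the two numbers shows the pendant ring matters greatly. A shift toward a weaker number is expected, a 2.9-fold higher number from compound 2 to compound 4 (0.47 log units; beyond the scatter), but with low confidence. For compound 4 the expected value in this assay is 5000 nM, ranging from 1500 nM to 20000 nM.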

Compound 4, half-maximal inhibitory concentration: 10600 nM
Compound 4: the middle estimate sits 2.1-fold (0.33 log units) below what was measured; measured number inside the range.
By their numbers in this assay, from the lowest: compounds 3 and 2 (each within the scatter of the next); then compound 4. At a limit, above all of these: compound 1.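

In this assay, the carbon next to the ring nitrogen and next to the ring oxygen responds strongly to a change of ring size when the starting group is an active aryl arm: furan-2-yl in place of 3-fluoro-4-methoxyphenyl gives a 6.2-fold higher number from compound 2 to compound 4 (0.79 log units; beyond the scatter), and furan-2-yl in place of 4-aminophenyl gives a 10-fold higher number from compound 3 to compound 4 (1.01 log units; beyond the scatter). Compound 1 goes against any simple preference for a six-membered ring here, since furan-2-yl in place of 3-methoxyphenyl gives an at least 2.3-fold lower number from compound 1 to compound 4 (0.37 log units; beyond the scatter), so the identity of the substituted phenyl matters as much as the ring size. That last step starts from a limit, not a number: the limit of > 25000 nM in this assay, at which 1 of the 4 values shown sits.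

Still open, going by these compounds, is whether the higher number of compound 4 follows from the five-membered ring itself or from the smaller group, a question that unsubstituted phenyl, thiophen-2-yl or a furan-2-yl bearing an amine would help separate. Also open is which part of 3-fluoro-4-methoxyphenyl accounts for its difference from 3-methoxyphenyl, which 4-methoxyphenyl would address.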